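Fluoro for Methoxy on the Pendant Aryl Ring

This account rests on a few compounds, and the source may have more. Where it says the series, first, only, none or still open, it means among the compounds named here.

The two measured compounds share one core and differ only in the aryl group attached to it. Compound 1 `CCC1=C(O)c2c(oc(-c3cc(C)c(C)cc3C)cc2=O)C(CC)(CC)C1=O` gives 8.2 uM in a functional assay on KB cells (Homo sapiens) for antiproliferative activity, read by sulforhodamine B assay, with a stated time of 3 days; on this read-out lower numbers stand for an effect already at smaller amounts and higher numbers for an effect only at larger amounts of compound. Compound 2 `CCC1=C(O)c2c(oc(-c3ccc(OC)c(C)c3)cc2=O)C(CC)(CC)C1=O` gives 28.5 uM in this assay, the higher of the two numbers; the step of a 3.5-fold higher number from compound 1 to compound 2 (0.54 log units; beyond the scatter) exchanges the whole substitution pattern of that ring. Compound 3 `CCC1=C(O)c2c(oc(-c3ccc(F)c(C)c3)cc2=O)C(CC)(CC)C1=O` has not yet been measured. It differs from compound 2 by fluoro in place of methoxy on an aromatic carbon. Among the measured compounds shown here, no measured step bears directly on this exchange: the only step recorded, a 3.5-fold higher number from compound 1 to compound 2 (0.54 log units; beyond the scatter), replaces several groups at once, and neither measured compound carries a fluoro group. That step shows that changes on this ring can move the number modestly, but it gives no direction for a fluoro for methoxy exchange. The step of a 1.3-fold lower number from compound 2 to compound 3 (0.11 log units; within the scatter) is therefore expected to lie within the scatter, in no particular direction. Compound 3 is accordingly estimated to give 22 uM in this assay, with a range from 8 uM to 55 uM.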

Compound 3, concentration for half-maximal effect: 40.5 uM
Estimate against measurement, compound 3: 1.8-fold (0.27 log units) below; low and high end bracket the measured number.
By their numbers in this assay, from the lowest: compound 1; then compounds 2 and 3 (each within the scatter of the next).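

At the carbon para to a large group and ortho to a methyl group, the exchange of methoxy for fluoro can now be read directly in this assay: the step shows a 1.4-fold higher number from compound 2 to compound 3 (0.15 log units; within the scatter), so removing a group with 1 hydrogen-bond acceptor and putting a single fluorine in its place does not separate the two compounds on this read-out. The 4-fluoro-3-methylphenyl group also keeps the distance from the 2,4,5-trimethylphenyl group that the methoxy compound had shown, with a 4.9-fold higher number from compound 1 to compound 3 (0.69 log units; beyond the scatter), and this step lies beyond the scatter. No measurement given here explains either step.

The compounds shown leave open whether a different group in this same place, such as an amine, a carboxylic acid or a longer alkoxy chain, would stay with methoxy and fluoro in this assay or move away from them. They also leave open which of the differences between the aryl groups of compound 1 and compound 3 carries the larger step, as those groups differ in more than one place.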